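Working notes: the step from compound 3 to compound 4

The compounds below may be only part of what the source reports. "The series", "measured", "known", "first", "only" and "open" are said of these compounds alone.

compound 1 `Clc1ccc(-n2cc(COc3cccc4cnc(Nc5cccc(Cl)c5)nc34)nn2)cc1`: 24000 nM
compound 2 `Clc1cccc(Nc2ncc3cccc(OCc4cn(Cc5c(Cl)cccc5Cl)nn4)c3n2)c1`: 7000 nM
compound 3 `Clc1cccc(Nc2ncc3cccc(OCc4cn(-c5ccc(Br)cc5)nn4)c3n2)c1`: 14000 nM

In a functional assay on Huh-7 cells (Homo sapiens) for cytotoxicity, read by cell counting, with a stated time of 48 h (a lower number here means a stronger inhibitor, a higher number a weaker inhibitor), compound 3 gives 14000 nM and sits within the scatter of both other compounds. Only one measured gap goes beyond the scatter, and it is modest: a 3.4-fold lower number from compound 1 to compound 2 (0.54 log units; beyond the scatter).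

Compound 4 `COc1cccc(-n2cc(COc3cccc4cnc(Nc5cccc(Cl)c5)nc34)nn2)c1` is still to be measured. It carries 3-methoxyphenyl in place of 4-bromophenyl on an aromatic nitrogen. Among the measured compounds shown here, no measured compound carries a methoxy group, so the series offers no direct precedent for this change.

Two other steps give indirect guidance. Bromo in place of chloro on an aromatic carbon gave a 1.7-fold lower number from compound 1 to compound 3 (0.23 log units; within the scatter), within the scatter. Exchange of the whole group on the aromatic nitrogen, with 4-bromophenyl in place of 2,6-dichlorobenzyl, gave a 2.0-fold higher number from compound 2 to compound 3 (0.30 log units; within the scatter), also within the scatter. Changes on this nitrogen have so far moved the number modestly at most, although three compounds are a thin basis.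

The expected step in this assay is a 1.1-fold higher number from compound 3 to compound 4 (0.03 log units; within the scatter), which means no expected change beyond the scatter and no firm direction. For compound 4 the estimated value is 15000 nM, with an expected range from 6000 nM to 35000 nM.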

Compound 4, half-maximal inhibitory concentration: 23000 nM
Beside the measured number, compound 4's estimate is 1.5-fold (0.19 log units) below it; measured number inside the range.
By their numbers in this assay, from the lowest: compounds 2, 3, 4 and 1 (each within the scatter of the next, the first and the last beyond it).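

In this assay, 3-methoxyphenyl on the aromatic nitrogen brings the first oxygen and the first hydrogen-bond acceptor to this group, yet the reading against 4-bromophenyl is a 1.6-fold higher number from compound 3 to compound 4 (0.22 log units; within the scatter) and against 4-chlorophenyl is a 1.0-fold lower number from compound 1 to compound 4 (0.02 log units; within the scatter), so the three phenyl groups shown stay within the scatter of one another whatever their substituent. The only gap beyond the scatter to compound 4 is a 3.3-fold higher number from compound 2 to compound 4 (0.52 log units; beyond the scatter), which matches a 3.4-fold lower number from compound 1 to compound 2 (0.54 log units; beyond the scatter) and suggests a separation of 2,6-dichlorobenzyl from the phenyl groups, although compound 3 goes against this pattern with a 2.0-fold higher number from compound 2 to compound 3 (0.30 log units; within the scatter). No measurement of any other kind bears on these numbers.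

Whether the separation of compound 2 belongs to the benzyl group itself or to its two chloro groups stays open, since the compounds shown include neither an unsubstituted benzyl nor a 2,6-dichlorophenyl group. Also open, on these data alone, is whether the flat reading across the phenyl groups would hold for an amine or a carboxylic acid on that ring, or for a methoxy group at another ring position, in this assay.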